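Amide replacement on the exocyclic ring nitrogen

The source may hold more compounds than are shown below. What is called first, only, known or untested is meant among the compounds shown, and "the series" means these compounds.

Compound 2 `CCN1CCN(CCCn2cnc3c(N4CCN(C5CCCC5)CC4)nc(NCc4ccc(N(CC)CC)cc4)nc32)CC1` is the point of departure. In an assay on HEK293 cells for antagonist activity at Toll-like receptor 9 (Homo sapiens), read by spectrophotometry (on this read-out lower numbers stand for stronger inhibition and higher numbers for weaker inhibition), compound 2 gives 150 nM, and compound 1 `CCN1CCN(CCCn2cnc3c(N4CCN(C5CCCC5)CC4)nc(N)nc32)CC1` gives 280 nM. Going by the values given here, the only measured step at this nitrogen is a 1.9-fold lower number from compound 1 to compound 2 (0.27 log units; within the scatter), so the two values sit within the scatter of each other and no ranking between them is claimed. Compound 3 `CCN1CCN(CCCn2cnc3c(N4CCN(C5CCCC5)CC4)nc(NC(=O)c4ccc(CN(C)C)cc4)nc32)CC1` carries (4-((dimethylamino)methyl)phenyl)carbonyl in place of 4-(diethylamino)benzyl on a nitrogen on an aromatic ring. Among the compounds with values here, since the single step that bears on this position stayed within the scatter, no change beyond the scatter is expected in this assay. Compound 3 is therefore estimated at 200 nM, with a range from 80 nM to 500 nM. The expected step is a 1.3-fold higher number from compound 2 to compound 3 (0.12 log units; within the scatter).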

Compound 3, half-maximal inhibitory concentration: 60 nM
Estimate against measurement, compound 3: 3.3-fold (0.52 log units) above; measured number outside the range, below it.
By their numbers in this assay, from the lowest: compound 3; then compounds 2 and 1 (each within the scatter of the next).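

In this assay, going by these compounds alone, this nitrogen does respond to its substituent: (4-((dimethylamino)methyl)phenyl)carbonyl in place of 4-(diethylamino)benzyl gives a 2.5-fold lower number from compound 2 to compound 3 (0.40 log units; beyond the scatter), the first step at this position beyond the scatter. The same carbonyl group in place of hydrogen gives a 4.7-fold lower number from compound 1 to compound 3 (0.67 log units; beyond the scatter), whereas the benzyl group in place of hydrogen stayed within the scatter. No supporting data bear on the origin of this gain.

Going by these compounds, the carbonyl and the dimethylaminomethyl group change together, so their separate contributions stay open. Also open, on these data alone, is how a morpholine in place of the dimethylamino group would read.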